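Two Inactive Amides and a Methoxy Analogue

A few compounds are considered here, and "the series" means these few. Any claim that something is new, unique, unknown or untested is made for them only; others in the source may bear on it.

Compound 1 `COc1ccc(Br)cc1C(=O)Nc1ccccc1`: > 100000 nM
Compound 2 `O=C(Nc1cccc(Cl)c1)c1cc(Br)ccc1O`: > 100000 nM

In an assay for inhibition of HSP60/HSP10 (Homo sapiens), with a stated time of 60 min (on this read-out higher numbers stand for weaker inhibition and lower numbers for stronger inhibition), compound 1 gives > 100000 nM, which is a limit of the assay rather than a measured number. Compound 2 gives > 100000 nM in this assay, again only a limit. For the measured compounds named here, both measured values sit at the same limit (the limit of > 100000 nM in this assay, at which 2 of the 2 values shown sit), so compound 2 stands at the limit with no number to place it, and no step between measured compounds can be drawn here.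

Compound 3 `COc1ccc(Br)cc1C(=O)Nc1cccc(Cl)c1` differs from compound 2 by methyl in place of hydrogen on an oxygen on an aromatic ring. Compound 3 is expected to stay near the limit, because compound 1, which also carries methoxy, gives > 100000 nM there. The step that the limit leaves unreadable from compound 2 to compound 3 is expected to be none beyond the scatter. Compound 3 is estimated at 150000 nM, in the range from 50000 nM to 500000 nM, most likely reported only as a limit.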

Compound 3, half-maximal inhibitory concentration: > 100000 nM
Compound 3 gave a limit, no number; the forecaster's own chance of this, stated with the estimate: 85%; the middle value does not contradict the limit.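

For the compounds shown here, no step from compound 2 to compound 3 or from compound 1 to compound 3 can be read, because all three compounds share one limit: the limit of > 100000 nM in this assay, at which 3 of the 3 values shown sit. On these data alone, whether hydroxy, methoxy or chloro affects inhibition at all stays open, with no actual number to compare.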